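Swapping methoxy for isopropoxy on compound 3

This account rests on a few compounds, and the source may have more. Where it says the series, first, only, none or still open, it means among the compounds named here.

Measured in a functional assay on Hs68 cells (Homo sapiens) for inhibition; on this read-out lower numbers stand for higher toxicity in this test and higher numbers for lower toxicity in this test:
- Compound 1 `COc1ccccc1CNC(=O)c1ccc2c(Cl)nccc2n1`: about 3.2 ug/mL
- Compound 2 `COc1ccccc1CNC(=O)c1ccc2c(OC)nccc2n1`: > 50 ug/mL, a limit
- Compound 3 `COc1ccccc1CNC(=O)C1=Cc2ccncc2CC1`: > 50 ug/mL, a limit

Compound 3 gives no number in this assay, only the limit > 50 ug/mL. This is the limit of > 50 ug/mL in this assay, at which 2 of the 3 values shown sit.

Compound 4 `CC(C)Oc1ccccc1CNC(=O)C1=Cc2ccncc2CC1` differs from compound 3 by one change, isopropyl in place of methyl on an oxygen on an aromatic ring, or methoxy to isopropoxy.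

For the measured compounds named here, only one measured step is available, and it bears on this change only indirectly. It is an at least 15-fold higher number from compound 1 to compound 2 (1.19 log units; beyond the scatter), a large step with methoxy in place of chloro on an aromatic carbon. Going by the values given here, that step lies elsewhere in the structure and on another core, and no measured step alters the group on this oxygen. Among the compounds with values here, no large step is therefore expected here, and compound 4 is expected to stay near the limit, perhaps with a somewhat lower number. The expected change is a number no higher from compound 3 to compound 4 (the limit leaves the size open). For compound 4 the estimated value is 50 ug/mL, with an expected range from 20 ug/mL to 100 ug/mL.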

Compound 4, half-maximal cytotoxic concentration: 12.5 ug/mL
The estimate for compound 4 lay 4.0-fold (0.60 log units) above the measured number, outside the stated range (below it).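

The group on this oxygen is not neutral in this assay: isopropyl in place of methyl gives an at least 4.0-fold lower number from compound 3 to compound 4 (0.60 log units; beyond the scatter), so this change alone brings out toxicity in this test on the core of compound 3. The earlier compounds shown here showed a change of this order only on an aromatic carbon of another core, as an at least 15-fold higher number from compound 1 to compound 2 (1.19 log units; beyond the scatter), and none of their steps touched this oxygen. The full size of the new step stays undetermined, since compound 3 carries only a limit: the limit of > 50 ug/mL in this assay, at which 2 of the 4 values shown sit.

Going by these compounds, it remains open whether a longer chain such as n-butyl on this oxygen would lower the number further, or whether an amine at the end of such a chain would raise it again. On these data alone, it is also open whether isopropyl in place of methyl would act in the same way on the core of compound 2.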